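This account rests on a few compounds, and the source may have more. Where it says the series, first, only, none or still open, it means among the compounds named here.

Measured compounds in a functional assay for agonist activity at P2Y purinoceptor 2 (Homo sapiens), read by FLIPR; a higher number here means that more compound is needed for the effect, a lower number that less compound is needed:
compound 1 `O=c1c2ccc(Cl)cc2ccn1[C@@H]1O[C@H](COP(=O)(O)OP(=O)(O)OP(=O)(O)O)[C@@H](O)[C@H]1O` with 541 nM;
compound 2 `N#Cc1ccc2c(=O)n([C@@H]3O[C@H](COP(=O)(O)OP(=O)(O)OP(=O)(O)O)[C@@H](O)[C@H]3O)ccc2c1` with 88 nM;
compound 3 `O=c1c2cc(Cl)ccc2ccn1[C@@H]1O[C@H](COP(=O)(O)OP(=O)(O)OP(=O)(O)O)[C@@H](O)[C@H]1O` with 10 nM.

Compound 3 stands lowest among these three in this assay, with compound 2 nearest and compound 1 furthest away. Compound 1 and compound 3 are built from the same atoms joined differently; the difference between the two cores is not broken down here.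

Between compound 1 and compound 2 one change is made: cyano in place of chloro on an aromatic carbon. In this assay this gave a 6.1-fold lower number from compound 1 to compound 2 (0.79 log units; beyond the scatter), a step beyond the usual scatter.

Compound 4 `N#Cc1ccc2ccn([C@@H]3O[C@H](COP(=O)(O)OP(=O)(O)OP(=O)(O)O)[C@@H](O)[C@H]3O)c(=O)c2c1` is not yet measured. It comes from compound 3 by the same change: cyano in place of chloro on an aromatic carbon. The place of the change reads the same in both pairs, so this is the same change made on a different core. Within the data shown here, the one example seen so far, from compound 1 to compound 2, points to a lower number; because of a 6.1-fold lower number from compound 1 to compound 2 (0.79 log units; beyond the scatter), a step of similar direction but somewhat uncertain size is expected here, since compound 3 already gives 10 nM and the change is known from one pair only. Compound 4 is therefore expected to show a 4.0-fold lower number from compound 3 to compound 4 (0.60 log units; beyond the scatter) in this assay. For compound 4 an estimate of 2.5 nM is made, expected to lie between 0.7 nM and 9 nM.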

Compound 4, half-maximal effective concentration: 12 nM
Beside the measured number, compound 4's estimate is 4.8-fold (0.68 log units) below it; the whole stated range lies below it.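

On the second core, cyano in place of chloro gave a 1.2-fold higher number from compound 3 to compound 4 (0.08 log units; within the scatter) in this assay, so the lower number seen on the core of compound 1 did not carry over to the core of compound 3. The two steps differ by more than their scatter, which shows that in this series the outcome of this change depends on the core that carries it: the same change on two cores in this assay, a 6.1-fold lower number (0.79 log units; beyond the scatter) from compound 1 to compound 2 and a 1.2-fold higher number (0.08 log units; within the scatter) from compound 3 to compound 4, 7.4-fold (0.87 log units) apart, beyond the scatter of two such steps

The pairs do not show why the two cores part ways, nor whether the size of the step is tied to the starting value, with compound 1 at 541 nM and compound 3 at 10 nM, and two pairs give no rule for what the change would do on a third core.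

The compounds shown carry only chloro or cyano on the aromatic ring, so it stays open whether a methoxy group, an amine or a carboxylic acid at the same carbons would follow either step. The triphosphate chain is the same in all four compounds, which leaves open how a shorter diphosphate chain would behave on either core.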